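Nitro to hydroxymethyl on the distal ring: cytotoxicity notes

The compounds below may be only part of what the source reports. "The series", "measured", "known", "first", "only" and "open" are said of these compounds alone.

Compound 1 `COc1cc(CC(O)c2ccc(-c3ccc([N+](=O)[O-])cc3)cc2)c([N+](=O)[O-])cc1OC` and compound 3 `COc1cc(CC(O)c2ccc(-c3cccc([N+](=O)[O-])c3)cc2)c([N+](=O)[O-])cc1OC` hold the same atoms joined differently; the two cores differ by 3-nitrophenyl in place of 4-nitrophenyl on an aromatic carbon. In an ADME assay on HeLa Rh cells (Homo sapiens) for cytotoxicity, read by microscopy (on this read-out lower numbers stand for higher toxicity in this test and higher numbers for lower toxicity in this test), compound 1 gives 21000 nM, and compound 3 gives 5500 nM, the step being a 3.8-fold lower number from compound 1 to compound 3 (0.58 log units; beyond the scatter). Compound 2 `COc1cc(CC(O)c2ccc(-c3ccc(CO)cc3)cc2)c([N+](=O)[O-])cc1OC` differs from compound 1 by hydroxymethyl in place of nitro on an aromatic carbon. In this assay compound 2 gives only a limit, > 244000 nM. The step of an at least 11-fold higher number from compound 1 to compound 2 (1.06 log units; beyond the scatter) is accordingly itself bounded (the limit of > 244000 nM in this assay, at which 1 of the 3 values shown sits). Compound 4 `COc1cc(CC(O)c2ccc(-c3cccc(CO)c3)cc2)c([N+](=O)[O-])cc1OC` differs from compound 3 by hydroxymethyl in place of nitro on an aromatic carbon. This is the same kind of change as from compound 1 to compound 2, but the place reads meta to a large group rather than para to a large group. A step of similar size is expected, an 18-fold higher number from compound 3 to compound 4 (1.26 log units; beyond the scatter), resting on an at least 11-fold higher number from compound 1 to compound 2 (1.06 log units; beyond the scatter), and it may again end at a limit. Compound 4 is therefore estimated at 100000 nM in this assay, between 30000 nM and 300000 nM.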

Compound 4, half-maximal cytotoxic concentration: 6000 nM
For compound 4 the middle estimate is 17-fold (1.22 log units) above the measured one, and the stated range ends above it.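

In this assay the change of nitro to hydroxymethyl does not carry from one core to the other: the same change on two cores in this assay, an at least 11-fold higher number (1.06 log units; beyond the scatter) from compound 1 to compound 2 and a 1.1-fold higher number (0.04 log units; within the scatter) from compound 3 to compound 4, at least 10-fold (1.02 log units) apart, beyond the scatter of two such steps

The steps read a 1.1-fold higher number from compound 3 to compound 4 (0.04 log units; within the scatter), with an at least 40-fold lower number from compound 2 to compound 4 (1.60 log units; beyond the scatter) and a 3.5-fold lower number from compound 1 to compound 4 (0.54 log units; beyond the scatter), so among these four compounds the high reading appears only with 4-(hydroxymethyl)phenyl.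

Compound 2 gives only a limit, > 244000 nM, and the size of its gap stays unknown; a single pair on each core sets no rule for the series: the limit of > 244000 nM in this assay, at which 1 of the 4 values shown sits.

Open, going by these compounds, is whether an amine, a carboxylic acid or a longer chain in place of hydroxymethyl would read like compound 2 or like compound 4. Also open, on these data alone, is whether such groups would respond to the same place on the distal ring in the same way.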